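A few compounds are considered here, and "the series" means these few. Any claim that something is new, unique, unknown or untested is made for them only; others in the source may bear on it.

Compound 3, `Nc1scc(CN2CCN(c3ccc(Cl)cc3F)CC2)c1C(=O)c1ccc(Cl)cc1`, was tested in a functional assay on CHO cells with adenosine receptor A1 (Homo sapiens) as the target, read by cAMP accumulation and immunoassay, with a stated time of 6 min, tested at 1 uM (a higher number here means a weaker effect of the compound at the concentration tested, a lower number a stronger effect), and gave -57%. On the numbers available it stands level with compound 1, `Nc1scc(CN2CCN(c3cccc(Cl)c3Cl)CC2)c1C(=O)c1ccc(Cl)cc1`, which gave -57%; the two together are the lowest of the three measured values, with no change at the digits printed from compound 1 to compound 3 (within the scatter). Compound 2, `Nc1scc(CN2CCN(c3ccc(F)cc3Cl)CC2)c1C(=O)c1ccc(Cl)cc1`, gave -39%, so that a number 18 percentage points lower from compound 2 to compound 3 (beyond the scatter), while a number 18 percentage points higher from compound 1 to compound 2 (beyond the scatter).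

Compound 4, `Nc1scc(CN2CCN(c3ccccc3C(F)(F)F)CC2)c1C(=O)c1ccc(Cl)cc1`, differs from compound 3 in one place: 2-(trifluoromethyl)phenyl in place of 4-chloro-2-fluorophenyl on an amine nitrogen in a ring. Among the compounds with values here, all three measured steps concern exchanges of one halogen pattern for another on the same phenyl attached to the ring nitrogen, and none brings in a trifluoromethyl group, so no measured step matches this change directly. Those halogen exchanges shifted the read-out by at most a modest amount, as seen in a number 18 percentage points higher from compound 1 to compound 2 (beyond the scatter), which suggests that this aryl position tolerates variation with moderate consequences. Compound 4 is therefore expected to stay near compound 3, with an estimated step of a number 7 percentage points higher from compound 3 to compound 4 (within the scatter). The estimate for compound 4 in this assay is -50%, within a range from -72% to -28%.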

Compound 4, a percentage reported as activity, at one concentration (the size of the read-out at that concentration, not a potency): -39%
Beside the measured number, compound 4's estimate is 11 percentage points below it; the measured number falls inside the stated range.
By their numbers in this assay, from the lowest: compounds 1 and 3 (each within the scatter of the next); then compounds 2 and 4 (each within the scatter of the next).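

In this assay, within the data shown here, the step of a number 18 percentage points higher from compound 3 to compound 4 (beyond the scatter) and the step of a number 18 percentage points higher from compound 1 to compound 4 (beyond the scatter) show that this position also responds when the halogen patterns give way to 2-(trifluoromethyl)phenyl, a kind of group the earlier compounds did not cover. The step of no change at the digits printed from compound 2 to compound 4 (within the scatter) places this group level with the 2-chloro-4-fluorophenyl of compound 2, so two different aryl groups share a read-out that lies apart from that of compound 1 and compound 3. Nothing available explains these differences.

Going by these compounds, whether a phenyl carrying a methoxy group or a nitrile would stay with compound 4 or return to the level of compound 3 remains open. Also open, on these data alone, is whether these differences at one concentration would hold across a full concentration range.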